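This account rests on a few compounds, and the source may have more. Where it says the series, first, only, none or still open, it means among the compounds named here.

In an ADME assay on Vero cells (Chlorocebus sabaeus) for cytotoxicity, read by CellTiter-Glo, with a stated time of 72 h (a lower number here means that less compound is tolerated, a higher number that more compound is tolerated), compound 1 `CCOC(=O)Nc1cc(NC(C)CCCN(CC)CC)c2nc(-c3ccco3)c(-c3ccco3)nc2n1` reaches only a limit of the assay, > 40000 nM. Compound 2 `CCOC(=O)Nc1cc(NC(C)CCCN(CC)CC)c2nc(-c3cccs3)c(-c3cccs3)nc2n1` likewise gives only a limit, > 40000 nM. Compound 3 `CCOC(=O)Nc1cc(NCCCCN(CC)CC)c2nc(-c3ccccc3)c(-c3ccccc3)nc2n1` gives a number, 1800 nM. Compound 2 therefore stands at the limit of > 40000 nM in this assay, at which 2 of the 3 values shown sit, the most tolerated end of what this assay can report.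

Compound 4 `CCOC(=O)Nc1cc(NCCN(C)C)c2nc(-c3cccs3)c(-c3cccs3)nc2n1` has not yet been measured. It differs from compound 2 in one place (2-(dimethylamino)ethyl in place of 4-(diethylamino)-1-methylbutyl on a nitrogen on an aromatic ring). Going by the values given here, no measured pair here shows what such a change does, so the size of the step cannot be read from the data. The expected step of a number no higher from compound 2 to compound 4 (the limit leaves the size open) is none beyond the scatter, most likely another limit. Compound 4 is estimated at 40000 nM, between 12000 nM and 100000 nM.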

Compound 4, half-maximal cytotoxic concentration: 1600 nM
For compound 4 the middle estimate is 25-fold (1.40 log units) above the measured one; the whole stated range lies above it.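

In this assay, the group on this nitrogen on an aromatic ring proves able to decide how much compound the cells tolerate: 2-(dimethylamino)ethyl in place of 4-(diethylamino)-1-methylbutyl gives an at least 25-fold lower number from compound 2 to compound 4 (1.39 log units; beyond the scatter). Going by these compounds alone, this is the first pair here that differs in one place, so it is the first direct reading of any such change. Its full size stays open because compound 2 gives only a limit of the assay: the limit of > 40000 nM in this assay, at which 2 of the 4 values shown sit.

As far as these compounds go, it remains open whether the shorter chain or the smaller amine end accounts for the step. A 2-(diethylamino)ethyl group on the same nitrogen would help separate the two.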